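The compounds below may be only part of what the source reports. "The series", "measured", "known", "first", "only" and "open" are said of these compounds alone.

Compound 1 `NCc1c[nH]c2ccc(F)cc12`: in an assay on isolated protein for inhibition of Myeloperoxidase (Homo sapiens) (on this read-out higher numbers stand for weaker inhibition and lower numbers for stronger inhibition), compound 1 gives > 1000 nM, which is a limit of the assay rather than a number.
Compound 2 `CCNCCCc1c[nH]c2ccc(F)cc12`: in this assay compound 2 gives 190 nM.

Compound 2 holds the only actual number shown; the other value is a limit. For the measured compounds named here, the single measured step, an at least 5.2-fold lower number from compound 1 to compound 2 (0.72 log units; beyond the scatter), links the longer chain carrying ethylamino to stronger inhibition than the short chain carrying amino. Compound 3 `NCCCCc1c[nH]c2ccc(F)cc12` differs from compound 2 by aminomethyl in place of ethylamino on a saturated chain carbon, three bonds along the chain from an aromatic carbon, so it keeps a long chain but returns to a plain amino group, as in compound 1. That measured step bears on the change only in part, since it altered chain length and amine substitution together, and one of its two values is the limit (the limit of > 1000 nM in this assay, at which 1 of the 2 values shown sits). The expected step of a 2.1-fold higher number from compound 2 to compound 3 (0.32 log units; beyond the scatter) is therefore a modest move toward weaker inhibition. Compound 3 is estimated at 400 nM, within 150 nM to 1500 nM.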

Compound 3, half-maximal inhibitory concentration: 12 nM
Compound 3: the middle estimate sits 33-fold (1.52 log units) above what was measured; measured number outside the range, below it.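

In this assay, the change at this carbon gives a 16-fold lower number from compound 2 to compound 3 (1.20 log units; beyond the scatter), so a long chain alone does not fix the result: what sits at its end matters, and here 3-aminopropyl far outdoes 2-(ethylamino)ethyl. Compound 1 and compound 3 both end in a plain amino group and differ in chain, and the step of an at least 83-fold lower number from compound 1 to compound 3 (1.92 log units; beyond the scatter) shows that lengthening to 3-aminopropyl brings a large gain. The size of that gain is only a bound: the limit of > 1000 nM in this assay, at which 1 of the 3 values shown sits.

The step to compound 3 both moves the nitrogen along the chain and removes its ethyl group, so a chain ending in methylamino would help to separate these two changes. From the compounds shown here alone, how a longer chain ending in an amine would fare, and whether a hydroxyl or carboxylic acid could replace the amine, stay open.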